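The source may hold more compounds than are shown below. What is called first, only, known or untested is meant among the compounds shown, and "the series" means these compounds.

Measured in a functional assay on SW1573 cells (Homo sapiens) for antiproliferative activity, read by sulforhodamine B assay, with a stated time of 48 h; on this read-out lower numbers stand for stronger inhibition of growth and higher numbers for weaker inhibition of growth:

Compound 1, `CCC(C#CC(=O)OC)O/C=C/C(=O)OC`: 540 nM
Compound 2, `COC(=O)C#CC(CC(C)C)O/C=C/C(=O)OC`: 380 nM
Compound 3, `COC(=O)C#CC(O/C=C/C(=O)OC)C(C)C`: 750 nM

All three share one core and differ only in the side group on the saturated chain carbon. Compound 3 carries the highest number of the three, but its distances to compound 1 and compound 2 are within the scatter, so no ordering is drawn from them. The step of a 1.4-fold higher number from compound 2 to compound 1 (0.15 log units; within the scatter) is methyl in place of isopropyl on a saturated chain carbon, two bonds along the chain from an oxygen on an unsaturated carbon and a triple-bonded carbon. The step of a 2.0-fold higher number from compound 2 to compound 3 (0.30 log units; within the scatter) is isopropyl in place of isobutyl on a saturated chain carbon bound to an oxygen on an unsaturated carbon and a triple-bonded carbon.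

Compound 4, `COC(=O)C#CC(C)O/C=C/C(=O)OC`, is not yet measured. Against compound 3 the change is methyl in place of isopropyl on a saturated chain carbon bound to an oxygen on an unsaturated carbon and a triple-bonded carbon. Against the change from compound 2 to compound 1 this is the same kind of change, not the same: there the place was two bonds along the chain from an oxygen on an unsaturated carbon and a triple-bonded carbon, here the saturated chain carbon is bound to that oxygen and the triple-bonded carbon. The earlier step of a 1.4-fold higher number from compound 2 to compound 1 (0.15 log units; within the scatter) stayed within the scatter, so a step of similar size is expected from compound 3 to compound 4, namely a 1.3-fold higher number from compound 3 to compound 4 (0.12 log units; within the scatter). On that basis compound 4 is estimated at 1000 nM in this assay, with a range from 400 nM to 2500 nM.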

Compound 4, concentration for 50% growth inhibition: 1700 nM
For compound 4 the middle estimate is 1.7-fold (0.23 log units) below the measured one; the measured number falls inside the stated range.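

In this assay the two cases of methyl in place of isopropyl cannot be told apart in size: the same change on two cores in this assay, a 1.4-fold higher number (0.15 log units; within the scatter) from compound 2 to compound 1 and a 2.3-fold higher number (0.36 log units; beyond the scatter) from compound 3 to compound 4, 1.6-fold (0.20 log units) apart, within the scatter of two such steps This agrees with the change carrying from one core to the other, but it rests on a single pair of steps at two different places, and only the later step, a 2.3-fold higher number from compound 3 to compound 4 (0.36 log units; beyond the scatter), lies beyond the scatter, so it does not show a fixed step size or a general rule. Compound 4, with methyl on the saturated chain carbon, is the weakest of the four, as the remaining steps also show: a 4.5-fold higher number from compound 2 to compound 4 (0.65 log units; beyond the scatter) and a 3.1-fold higher number from compound 1 to compound 4 (0.50 log units; beyond the scatter), both beyond the scatter.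

The compounds shown cover only small saturated carbon side groups, which leaves open how a longer chain, a phenyl ring or an amine on that carbon would behave. Also open, going by these compounds, is whether a carboxylic acid in place of either methyl ester would leave these steps unchanged.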